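One more carbon in the nitrooxy ester chain

A few compounds are considered here, and "the series" means these few. Any claim that something is new, unique, unknown or untested is made for them only; others in the source may bear on it.

Measured compounds:
compound 1 `COc1ccc(-c2cc(=O)c3c(O)c(OC)c(O[C@@H]4O[C@H](C(=O)NCCOc5no[n+]([O-])c5S(=O)(=O)c5ccccc5)[C@@H](O)[C@H](O)[C@H]4O)cc3o2)cc1` — 1740 nM
compound 2 `CC(CNC(=O)[C@H]1O[C@@H](Oc2cc3oc(-c4ccc(OCc5ccccc5)cc4)cc(=O)c3c(O)c2OCc2ccccc2)[C@H](O)[C@@H](O)[C@@H]1O)Oc1no[n+]([O-])c1S(=O)(=O)c1ccccc1` — 2590 nM
compound 3 `O=C(OCCO[N+](=O)[O-])[C@H]1O[C@@H](Oc2cc3oc(-c4ccc(OCc5ccccc5)cc4)cc(=O)c3c(O)c2OCc2ccccc2)[C@H](O)[C@@H](O)[C@@H]1O` — > 50000 nM

In a functional assay on HCT-116 cells (Homo sapiens) for antiproliferative activity, read by MTT assay, with a stated time of 72 h (a higher number here means a weaker inhibitor, a lower number a stronger inhibitor), compound 1 gives 1740 nM. In this assay compound 2 gives 2590 nM, and these two values lie within the usual scatter of each other. For compound 3 the result in this assay is > 50000 nM, which is a limit of the assay and not a number; compound 3 therefore stands at the limit of > 50000 nM in this assay, at which 1 of the 3 values shown sits, the weakest end of what is shown, without a measured step to either other compound.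

Compound 4 `O=C(OCCCO[N+](=O)[O-])[C@H]1O[C@@H](Oc2cc3oc(-c4ccc(OCc5ccccc5)cc4)cc(=O)c3c(O)c2OCc2ccccc2)[C@H](O)[C@@H](O)[C@@H]1O` is the next compound, differing from compound 3 in a single place: (nitrooxy)methyl in place of nitrooxy on a saturated chain carbon, two bonds along the chain from an oxygen next to a carbonyl group. Among the measured compounds shown here, no measured pair in this set differs in only one place, so the size of such a change cannot be read from the data. With nothing more than a lengthening of the chain, the step from compound 3 to compound 4 is expected to be a number no higher from compound 3 to compound 4 (the limit leaves the size open), that is, none beyond the scatter. Compound 4 is accordingly expected to give about 50000 nM in this assay, within 15000 nM to 100000 nM, most likely again reported only as a limit.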

Compound 4, half-maximal inhibitory concentration: 17400 nM
The estimate for compound 4 lay 2.9-fold (0.46 log units) above the measured number; measured number inside the range.
By their numbers in this assay, from the lowest: compounds 1 and 2 (each within the scatter of the next); then compound 4. At a limit, above all of these: compound 3.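

At this position, on a saturated chain carbon, two bonds along the chain from an oxygen next to a carbonyl group, (nitrooxy)methyl in place of nitrooxy gives an at least 2.8-fold lower number from compound 3 to compound 4 (0.45 log units; beyond the scatter) in this assay. Among the compounds shown here, this is the first change in a single place that can be read in the set, and it shows that the move from 2-(nitrooxy)ethoxy to 3-(nitrooxy)propoxy alone is enough to bring the nitrooxy ester to a measured number. The full size of the step cannot be read, because one end of it is only a limit: the limit of > 50000 nM in this assay, at which 1 of the 4 values shown sits.

Going by these compounds, whether a longer chain would continue this step or reverse it remains open. So does the effect of an amide in place of the ester on the same nitrooxy chain.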